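Piperazine for piperidine: cytotoxicity notes on two pairs

This account rests on a few compounds, and the source may have more. Where it says the series, first, only, none or still open, it means among the compounds named here.

Compound 1 `CC(C)(C)[Si](CCc1c(N2CCCCC2)nc2ccc(Cl)cc2c1-c1ccccc1Cl)(c1ccccc1)c1ccccc1` gives > 968000 nM in an ADME assay on HepG2 2.2.15 cells (Homo sapiens) for cytotoxicity (a lower number here means that less compound is tolerated, a higher number that more compound is tolerated), which is a limit of the assay.
Compound 2 `CC(C)(C)[Si](CCc1c(N2CCNCC2)nc2ccc(Cl)cc2c1-c1ccccc1Cl)(c1ccccc1)c1ccccc1` gives < 18800 nM in this assay, again a limit of the assay.
Compound 3 `OCCc1c(N2CCCCC2)nc2ccc(Cl)cc2c1-c1ccccc1Cl` gives 155000 nM in this assay.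

The change piperazin-1-yl in place of piperidin-1-yl on an aromatic carbon produced an at least 51-fold lower number from compound 1 to compound 2 (1.71 log units; beyond the scatter). Its true size is open at both ends, because the limit of < 18800 nM in this assay, at which 1 of the 3 values shown sits, and the limit of > 968000 nM in this assay, at which 1 of the 3 values shown sits, mark the ends of this step. The difference between the core of compound 1 and the core of compound 3 is not broken down here. Compound 4 `OCCc1c(N2CCNCC2)nc2ccc(Cl)cc2c1-c1ccccc1Cl` carries the same kind of change, (piperazin-1-yl in place of piperidin-1-yl on an aromatic carbon), with a 2-hydroxyethyl group where compound 1 has a large group. A sizeable step a 13-fold lower number from compound 3 to compound 4 (1.11 log units; beyond the scatter) is expected, resting on the step of an at least 51-fold lower number from compound 1 to compound 2 (1.71 log units; beyond the scatter). Compound 4 is thus estimated at 12000 nM, between 3000 nM and 50000 nM.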

Compound 4, half-maximal cytotoxic concentration: < 5000 nM
Compound 4: no number, only a limit; the forecaster's own chance of this, stated with the estimate: 45%; middle value at least 2.4-fold (0.38 log units) away from the limit.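

In this assay, piperazin-1-yl in place of piperidin-1-yl on the core with the 2-hydroxyethyl group gives an at least 31-fold lower number from compound 3 to compound 4 (1.49 log units; beyond the scatter). The value of compound 4, < 5000 nM, is a limit of the assay and not a number. The change therefore lowers the number in the same direction on both cores shown, but two cores do not establish a rule for the series, and the sizes of the two steps cannot be compared: the same change on two cores in this assay, an at least 51-fold lower number (1.71 log units; beyond the scatter) from compound 1 to compound 2 and an at least 31-fold lower number (1.49 log units; beyond the scatter) from compound 3 to compound 4; the limit leaves it open whether they differ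

The compounds shown leave open how morpholin-4-yl or 4-methylpiperazin-1-yl in place of piperidin-1-yl would read on either core. Also open, from the compounds shown here alone, is whether the change carries over to a core with a carboxylic acid or a longer chain in place of the 2-hydroxyethyl group.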